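Azidomethyl in place of the alkenyl group on compound 1

The compounds below may be only part of what the source reports. "The series", "measured", "known", "first", "only" and "open" are said of these compounds alone.

Going by the values given here, in a functional assay on HCT-116 cells (Homo sapiens) for inhibition, read by MTT assay, with a stated time of 48 h (on this read-out higher numbers stand for weaker inhibition and lower numbers for stronger inhibition), compound 1 (`COc1ccc(CN(C(=O)C=C(C)C)c2cc(OC)c(OC)c(OC)c2)cc1O`) gives 290 nM, the only actual number so far. Compound 2 (`COc1cc(NCc2ccc(Br)cc2)cc(OC)c1OC`) reads > 80000 nM, which is a limit of the assay. Compound 3 (`COc1ccc(CN(C(=O)CN=[N+]=[N-])c2cc(OC)c(OC)c(OC)c2)cc1O`) keeps the core of compound 1, with azidomethyl in place of 2-methylprop-1-en-1-yl on a carbonyl carbon. Among the compounds with values here, no measured step covers this change, so the expectation rests on compound 1 alone at 290 nM. In this assay a moderate loss of inhibition is expected, estimated as a 5.2-fold higher number from compound 1 to compound 3 (0.71 log units; beyond the scatter). For compound 3 the estimated value is 1500 nM, with an expected range of 300 nM to 10000 nM.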

Compound 3, half-maximal inhibitory concentration: 410 nM
Estimate against measurement, compound 3: 3.7-fold (0.56 log units) above, within the range that was stated.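

In this assay, azidomethyl in place of 2-methylprop-1-en-1-yl on a carbonyl carbon gives a 1.4-fold higher number from compound 1 to compound 3 (0.15 log units; within the scatter). This position therefore accepts two groups of quite different atoms, and inhibition in the core of compound 1 does not rest on the 2-methylprop-1-en-1-yl group alone. Nothing at hand bears on a cause for this step. Still open, going by these compounds, is whether a plain methyl, an amine, a carboxylic acid or a longer chain on the same carbonyl carbon would read alike.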